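This account rests on a few compounds, and the source may have more. Where it says the series, first, only, none or still open, it means among the compounds named here.

Working notes on the chain-extended esters. In an in vitro ADME assay on microsomes from liver (Homo sapiens) for metabolic stability (a higher number here means that the compound lasts longer, a lower number that the compound disappears faster), compound 1 `CCc1nc(N)nc(N)c1-c1ccc2c(c1)N(CCC(=O)OC)CCC2` gives 0.0833 h and compound 2 `CCc1nc(N)nc(N)c1-c1ccc2c(c1)N(CCCC(=O)OC)CCC2` gives 0.0833 h, so compound 2 stands level with its only measured neighbour at the digits shown. The next analogue is compound 3 `CCc1nc(N)nc(N)c1-c1ccc2c(c1)N(CCCCC(=O)OC)CCC2`, not yet measured. Its change from compound 2 is (methoxycarbonyl)methyl in place of methoxycarbonyl on a saturated chain carbon, three bonds along the chain from a nitrogen on an aromatic ring in a ring. In words, this is (methoxycarbonyl)methyl in place of methoxycarbonyl on a saturated chain carbon, three bonds along the chain from a nitrogen on an aromatic ring in a ring. Cut further out, it reads 3-(methoxycarbonyl)propyl to 4-(methoxycarbonyl)butyl. Among the measured compounds shown here, one measured step bears on this: no change at the digits printed from compound 1 to compound 2 (within the scatter), the same replacement made two bonds along the chain from that nitrogen. A single step is thin evidence, but it gives no reason to expect movement beyond the scatter in this assay, and it favours no direction. The expected step is no change at the digits printed from compound 2 to compound 3 (within the scatter). For compound 3 the estimate is 0.0833 h, with an expected range from 0.05 h to 0.16 h.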

Compound 3, half-life: 0.0833 h
For compound 3 middle estimate and measured number coincide at the digits printed, and the stated range covers the measured number.
By their numbers in this assay, from the lowest: compounds 1, 2 and 3 (each within the scatter of the next).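

In this assay, the replacement of methoxycarbonyl by (methoxycarbonyl)methyl now reads the same at a second place, three bonds along the chain from the nitrogen on the aromatic ring, with no change at the digits printed from compound 2 to compound 3 (within the scatter). Over the whole span from 2-(methoxycarbonyl)ethyl to 4-(methoxycarbonyl)butyl, the two smaller steps do not add up to a larger one, with no change at the digits printed from compound 1 to compound 3 (within the scatter), so the flat reading no longer rests on a single step, though it is shown only for these three compounds. No supporting measurement is available to explain why the half-life stays level across these chain lengths.

The compounds shown leave open whether a longer chain than 4-(methoxycarbonyl)butyl, or a branched chain of similar length, would separate from this level. They also leave open whether replacing the methyl ester at the chain end with a carboxylic acid, an amide or an ethyl ester would change the reading in this assay, since every compound here carries the same methyl ester on the same core.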